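Swapping Fluoro for Trifluoromethyl: What Step to Expect

The compounds below may be only part of what the source reports. "The series", "measured", "known", "first", "only" and "open" are said of these compounds alone.

Three compounds have been measured in a functional assay on PC-3 cells (Homo sapiens) for inhibition, read by MTT assay, with a stated time of 72 h; a lower number here means a stronger inhibitor, a higher number a weaker inhibitor:

Compound 1 `C=CC(=O)Nc1cccc(NC(=O)CSc2nc(Nc3ccccc3Br)c3ccccc3n2)c1` gives 17100 nM.
Compound 2 `C=CC(=O)Nc1cccc(NC(=O)CSc2nc(Nc3cccc(F)c3)c3ccccc3n2)c1` gives 5370 nM.
Compound 3 `C=CC(=O)Nc1cccc(NC(=O)CSc2nc(Nc3ccc(F)cc3)c3ccccc3n2)c1` gives 8240 nM.

The three share one core and differ only in the aryl group carried on the amino nitrogen. Compound 3 stands second highest of the three numbers: its step from compound 2 is a 1.5-fold higher number from compound 2 to compound 3 (0.19 log units; within the scatter), so those two sit within the scatter of each other, while a 2.1-fold lower number from compound 1 to compound 3 (0.32 log units; beyond the scatter) sets compound 3 apart from compound 1.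

Compound 4 `C=CC(=O)Nc1cccc(NC(=O)CSc2nc(Nc3ccc(C(F)(F)F)cc3)c3ccccc3n2)c1` is the next compound. The change is trifluoromethyl in place of fluoro on an aromatic carbon, so the (4-fluorophenyl)amino becomes (4-(trifluoromethyl)phenyl)amino. Among the measured compounds shown here, none of the measured steps makes this exact exchange. For the measured compounds named here, the steps that bear on it are those varying the same aryl group: a 3.2-fold lower number from compound 1 to compound 2 (0.50 log units; beyond the scatter) and a 2.1-fold lower number from compound 1 to compound 3 (0.32 log units; beyond the scatter), both modest, and a 1.5-fold higher number from compound 2 to compound 3 (0.19 log units; within the scatter), within the scatter. Across these three examples the aryl substituent moves the number only modestly, so for this step no change beyond the scatter is expected in this assay. Compound 4 is therefore expected to give 8500 nM, with a range from 3000 nM to 25000 nM, which means an expected step of a 1.0-fold higher number from compound 3 to compound 4 (0.01 log units; within the scatter).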

Compound 4, half-maximal inhibitory concentration: 12500 nM
The estimate for compound 4 lay 1.5-fold (0.17 log units) below the measured number, within the range that was stated.
By their numbers in this assay, from the lowest: compounds 2, 3, 4 and 1 (each within the scatter of the next, the first and the last beyond it).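

In this assay, among the compounds shown here, trifluoromethyl, with its 4 heavy atoms, in place of the single fluorine on this aromatic carbon, para to a large group, gives a 1.5-fold higher number from compound 3 to compound 4 (0.18 log units; within the scatter) and so no step that can be told from the scatter. Within this one exchange, then, the position takes the bigger group without a clear change, which the earlier compounds could not show, since none of them made this swap. Compound 4 does sit apart from one neighbour, with a 2.3-fold higher number from compound 2 to compound 4 (0.37 log units; beyond the scatter) on the aryl group exchange, whereas a 1.4-fold lower number from compound 1 to compound 4 (0.14 log units; within the scatter) places it within the scatter of compound 1, and no measurement shown here offers a reason for either step.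

Still open, going by these compounds, is whether the exchange of fluoro for trifluoromethyl would give a similarly small step on the 3-fluorophenyl group of compound 2, where the aryl group carries its substituent at another place. Also open, on these data alone, is how this aromatic carbon responds to groups of a different kind, such as an amine or a carboxylic acid, since every substituent here is a halogen or trifluoromethyl.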